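From nitro to bromo on an aromatic carbon

This account rests on a few compounds, and the source may have more. Where it says the series, first, only, none or still open, it means among the compounds named here.

Measured and pending in a physicochemical assay for lipophilicity; on this read-out higher numbers stand for higher lipophilicity and lower numbers for lower lipophilicity:
Compound 1 `Cc1ccccc1C1=NC(c2ccccc2)CO1`: 3.68
Compound 2 `O=[N+]([O-])c1ccccc1C1=NC(c2ccccc2)CO1`: 2.83
Compound 3 `Brc1ccccc1C1=NC(c2ccccc2)CO1`: not yet measured

Of the two measured compounds, compound 2 stands lower, at 2.83, and its nearest neighbour is compound 1, at 3.68. The next structure, compound 3, keeps the core of compound 2 and makes a single change: bromo in place of nitro on an aromatic carbon. In short, it has bromo in place of nitro on an aromatic carbon, ortho to a large group.

Among the measured compounds shown here, one measured step bears on this change: a number 0.85 log units lower from compound 1 to compound 2 (beyond the scatter). That step is modest but beyond the scatter, and in it nitro took the place of methyl. In the new change nitro leaves instead of entering, so a step of similar size in the upward direction is expected in this assay. For the measured compounds named here, no measured compound carries bromo, and the expectation rests on that single step, so the range is kept wide. The estimated change is a number 0.87 log units higher from compound 2 to compound 3 (beyond the scatter). For compound 3 the expected value is 3.7, with an estimated range from 3.2 to 4.2.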

Compound 3, partition coefficient: 3.69
The estimate for compound 3 lay 0.01 log units above the measured number; the measured number falls inside the stated range.
By their numbers in this assay, from the lowest: compound 2; then compounds 1 and 3 (each within the scatter of the next).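

On an aromatic carbon ortho to a large group, compound 2 now stands apart from two neighbours rather than one in this assay: bromo in place of nitro gives a number 0.86 log units higher from compound 2 to compound 3 (beyond the scatter), a modest step beyond the scatter, as was the earlier change from methyl to nitro, a number 0.85 log units lower from compound 1 to compound 2 (beyond the scatter). Bromo in place of methyl gives a number 0.01 log units higher from compound 1 to compound 3 (within the scatter), so on this read-out the two groups cannot be told apart at this position, although they share neither the same atoms nor the same count of them, and only nitro, the one group of the three that carries hydrogen-bond acceptors, stands apart. No measurement is available that accounts for this grouping.

Among the compounds shown here, with only three groups compared at a single position, it remains open whether an amine, a carboxylic acid or a methoxy group would fall with nitro or with methyl and bromo in this assay. On these data alone, it also remains open whether the same exchanges of nitro, methyl and bromo would give steps of this size elsewhere on the shared core.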